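Fluoro in Place of Methyl on the Pendant Phenyl

The compounds below may be only part of what the source reports. "The series", "measured", "known", "first", "only" and "open" are said of these compounds alone.

Measured compounds:
Compound 1 `Cc1nc2sc(-c3ccccc3)nc2c(=O)[nH]1`, in an assay on CHO cells for displacement of a labelled ligand from adenosine receptor A1 (Homo sapiens), read by scintillation counting, with a stated time of 120 min, tested at 1 uM (on this read-out lower numbers stand for less inhibition and higher numbers for more inhibition at the one concentration tested (going by the name of the read-out)), compound 1 gives 11%.
Compound 2 `Cc1ccc(-c2nc3c(=O)[nH]c(C)nc3s2)cc1`, in this assay compound 2 gives 17%.

Compound 2 holds the higher of the two numbers, but the step of a number 6 percentage points higher from compound 1 to compound 2 (within the scatter) lies within the scatter, so the two measured compounds cannot be told apart on this read-out. Compound 3 `Cc1nc2sc(-c3ccc(F)cc3)nc2c(=O)[nH]1` has not yet been measured. It differs from compound 2 by fluoro in place of methyl on an aromatic carbon. Going by the values given here, the only measured step, a number 6 percentage points higher from compound 1 to compound 2 (within the scatter), concerns a different exchange at the same kind of position and stayed within the scatter, so it offers no guidance on direction and suggests that small substituents on that ring carry little weight here. On that basis the step of a number 3 percentage points lower from compound 2 to compound 3 (within the scatter) is expected to remain within the scatter. Compound 3 is therefore estimated at 14%, with a range from 2% to 28%.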

Compound 3, a percentage reported as inhibition, at one concentration (the size of the read-out at that concentration, not a potency): 1%
Estimate against measurement, compound 3: 13 percentage points above; the whole stated range lies above it.
By their numbers in this assay, from the lowest: compounds 3, 1 and 2 (each within the scatter of the next, the first and the last beyond it).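

In this assay, going by these compounds alone, the aromatic carbon para to a large group proves less indifferent than the earlier pair suggested: fluoro in place of methyl there gives a number 16 percentage points lower from compound 2 to compound 3 (beyond the scatter), the first step to pass beyond the scatter, though only a modest one. Hydrogen at this carbon cannot be separated from fluoro, as a number 10 percentage points lower from compound 1 to compound 3 (within the scatter) shows, nor from methyl, as a number 6 percentage points higher from compound 1 to compound 2 (within the scatter) shows, so only the methyl and fluoro compounds can be told apart. Nothing at hand accounts for the difference between these two groups.

The compounds shown leave open how a methoxy group, an amine or a carboxylic acid at this carbon would read. They also leave open whether a longer chain in place of the methyl on the shared core would change the picture.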